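The compounds below may be only part of what the source reports. "The series", "measured", "known", "first", "only" and "open" are said of these compounds alone.

Of the compounds shown here, three sharing one core have been measured in a functional assay on MDA-MB-231 cells (Homo sapiens) for antiproliferative activity, read by MTT assay, with a stated time of 48 h; on this read-out higher numbers stand for weaker inhibition of growth and lower numbers for stronger inhibition of growth. Compound 1 (`COC(=O)N1N=C(c2ccccc2)CC1c1cc(OC)c(OC)c(OC)c1`) gives 1080 nM, compound 2 (`CCOc1cccc(C2=NN(C(=O)OC)C(c3cc(OC)c(OC)c(OC)c3)C2)c1`) gives 190 nM, and compound 3 (`COC(=O)N1N=C(c2cccc(C)c2)CC1c1cc(OC)c(OC)c(OC)c1`) gives 140 nM. Compound 3 has the lowest of the three numbers, but that low end is shared: a 1.4-fold lower number from compound 2 to compound 3 (0.13 log units; within the scatter) stays within the scatter, whereas a 7.7-fold lower number from compound 1 to compound 3 (0.89 log units; beyond the scatter) goes beyond it.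

Compound 4 (`COC(=O)N1N=C(c2ccc(OC)c(OC)c2)CC1c1cc(OC)c(OC)c(OC)c1`) differs at one place: 3,4-dimethoxyphenyl in place of 3-methylphenyl on a carbon with a double bond to nitrogen, with 3,4-dimethoxyphenyl in place of 3-methylphenyl on a carbon with a double bond to nitrogen. The closest evidence is modest, since a 5.7-fold lower number from compound 1 to compound 2 (0.75 log units; beyond the scatter) shows what ethoxy in place of hydrogen did, and that step and the methyl step both lowered the number. Going by the values given here, no measured compound carries a dimethoxyphenyl group, so the data do not test this change directly. In this assay, only a small rise is therefore expected, probably within the scatter. The expected change is a 1.8-fold higher number from compound 3 to compound 4 (0.25 log units; within the scatter). Compound 4 is estimated at 250 nM, with an expected range of 80 nM to 800 nM.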

Compound 4, concentration for 50% growth inhibition: 9900 nM
Beside the measured number, compound 4's estimate is 40-fold (1.60 log units) below it; the whole stated range lies below it.
By their numbers in this assay, from the lowest: compounds 3 and 2 (each within the scatter of the next); then compound 1; then compound 4.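

In this assay, going by these compounds alone, the group on the carbon with a double bond to nitrogen proves far less tolerant than the earlier compounds suggested, since a 71-fold higher number from compound 3 to compound 4 (1.85 log units; beyond the scatter) and a 52-fold higher number from compound 2 to compound 4 (1.72 log units; beyond the scatter) separate 3,4-dimethoxyphenyl sharply from 3-methylphenyl and 3-ethoxyphenyl. Until now, both changes on the phenyl group had lowered the number, but a 9.2-fold higher number from compound 1 to compound 4 (0.96 log units; beyond the scatter) shows that a change at this position can also leave a compound well behind the plain phenyl group, so added groups here do not act in one direction. Nothing available explains this reversal.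

The compounds shown leave open whether either methoxy group of 3,4-dimethoxyphenyl alone would raise the number or whether the pair is needed. They also leave open how a chloro group, an amine or a carboxylic acid on this phenyl group would behave.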